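Benzyloxy to methyl-oxadiazolyl on the biaryl tail

This account rests on a few compounds, and the source may have more. Where it says the series, first, only, none or still open, it means among the compounds named here.

Notes on two amide compounds of one shared core, assayed in an ADME assay on BJ cells (Homo sapiens) for cytotoxicity, read by CellTiter-Glo and resazurin assay, with a stated time of 72 h; a lower number here means that less compound is needed, a higher number that more compound is needed for the effect. Compound 1 `CCOC(=O)CCCCCOc1cccc(CN(C(=O)c2ccc(-c3ccc4ccccc4c3)cc2)C(C)C)c1` carries a naphthyl tail. In this assay compound 1 reaches only the limit of the assay, > 26000 nM, and not a number. Compound 2 `CCOC(=O)CCCCCOc1cccc(CN(C(=O)c2ccc(-c3cccc(OCc4ccccc4)c3)cc2)C(C)C)c1` carries a benzyloxy-substituted phenyl tail instead. In this assay compound 2 likewise sits at the limit of the assay, > 26000 nM. Among the compounds with values here, compound 2 therefore stands nowhere that can be ranked: its value is a limit, and the one other value shown is a limit of the same kind, as the limit of > 26000 nM in this assay, at which 2 of the 2 values shown sit, summarises. Within the data shown here, no step between measured compounds is available.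

Compound 3 `CCOC(=O)CCCCCOc1cccc(CN(C(=O)c2ccc(-c3cccc(-c4nnc(C)o4)c3)cc2)C(C)C)c1` differs from compound 2 by 5-methyl-1,3,4-oxadiazol-2-yl in place of benzyloxy on an aromatic carbon. With both measured values at the limit, no direction can be read from the data; the expected step from compound 2 to compound 3 in this assay is a step that the limit leaves unreadable from compound 2 to compound 3, with no change beyond the scatter expected. Compound 3 is estimated at 30000 nM, within 12000 nM to 80000 nM, most likely again reported only as a limit.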

Compound 3, half-maximal effective concentration: > 26000 nM
Compound 3: a limit, no number (the forecaster's own chance of this, stated with the estimate: 75%); the middle value is on the limit's open side.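

No step can be read between compound 3 and either compound 2 or compound 1, as all three values are limits of the assay and not numbers: the limit of > 26000 nM in this assay, at which 3 of the 3 values shown sit.

The compounds shown leave open how the tails of compound 1, compound 2 and compound 3 rank in this assay and whether any change on the shared core gives a number there.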